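The source may report more compounds than this note shows. Statements on the series, on what has been measured and on what is new or still open speak of the compounds shown alone.

Working notes on the series in a functional assay on MDA-MB-231 cells (Homo sapiens) for antiproliferative activity, read by MTT assay, with a stated time of 48 h; a lower number here means a stronger inhibitor, a higher number a weaker inhibitor. Of the compounds shown here, two on the shared core have numbers so far: compound 1 `CN1CCN(c2ccc(-c3cc4c(N5CCN(S(=O)(=O)/C=C/c6ccccc6)CC5)ncnc4s3)cc2)CC1` gives 5900 nM, and compound 2 `CN1CCN(c2ccc(-c3cc4c(N5CCN(C(=O)Nc6ccc(C#N)cc6)CC5)ncnc4s3)cc2)CC1` gives 3930 nM. These two values lie within the scatter of each other, so compound 2 holds no separate rank in this pair.

Compound 3 `CN1CCN(c2ccc(-c3cc4c(N5CCN(C(=O)Nc6ccc(Cl)cc6)CC5)ncnc4s3)cc2)CC1` departs from compound 2 in one place: chloro in place of cyano on an aromatic carbon. This is chloro in place of cyano on an aromatic carbon, para to a large group, which turns (4-cyanophenyl)carbamoyl into (4-chlorophenyl)carbamoyl.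

Going by the values given here, the only measured step, a 1.5-fold lower number from compound 1 to compound 2 (0.18 log units; within the scatter), exchanges (2-phenylethenyl)sulfonyl for (4-cyanophenyl)carbamoyl on an amine nitrogen in a ring. Among the compounds with values here, it bears on this change only indirectly, as no measured pair varies the group at the cyano position. Since that whole-group exchange stayed within the scatter, no step beyond the scatter is expected in this assay, and no direction is favoured. The estimated step is a 1.1-fold lower number from compound 2 to compound 3 (0.05 log units; within the scatter). The estimate for compound 3 is 3500 nM, with an expected range of 1500 nM to 8000 nM.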

Compound 3, half-maximal inhibitory concentration: 5440 nM
The estimate for compound 3 lay 1.6-fold (0.19 log units) below the measured number, within the range that was stated.
By their numbers in this assay, from the lowest: compounds 2, 3 and 1 (each within the scatter of the next).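

In this assay, chloro in place of cyano on an aromatic carbon, para to a large group, gives a 1.4-fold higher number from compound 2 to compound 3 (0.14 log units; within the scatter). Going by these compounds alone, this is the first measured pair that varies this position directly, and it shows that, within this pair, the exchange of the two groups does not separate the compounds. The step on the amine nitrogen in a ring, (4-chlorophenyl)carbamoyl in place of (2-phenylethenyl)sulfonyl, gives a 1.1-fold lower number from compound 1 to compound 3 (0.04 log units; within the scatter), so with chloro in place of cyano on the carbamoyl side, that exchange also leaves the two compounds unseparated, and no evidence bears on the reason for either result.

As far as these compounds go, all three compounds remain within the scatter of one another, so the position has yet to show any effect that can be read in this assay, and whether it tolerates any group remains open beyond cyano and chloro. An amine or a carboxylic acid on that aromatic carbon, or a longer chain between the carbonyl and the aromatic ring, could show whether this part of the series can move the number beyond the scatter at all.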